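The source may hold more compounds than are shown below. What is called first, only, known or untested is meant among the compounds shown, and "the series" means these compounds.

Measured so far in a functional assay on A549 cells (Homo sapiens) for antiproliferative activity, read by MTT assay, with a stated time of 72 h; on this read-out higher numbers stand for weaker inhibition and lower numbers for stronger inhibition:
- compound 1 `CCCNC(=O)c1cc(Oc2ccc(NC(=O)c3nn(-c4ccc(C)cc4)c(=O)cc3C)cc2F)ccn1`: 18000 nM
- compound 2 `CCCNC(=O)c1cc(Oc2ccc(NC(=O)c3nn(-c4ccc(Br)cc4F)c(=O)cc3C)cc2F)ccn1`: 235000 nM

Compound 2 stands highest of the two, so it is the weaker inhibitor. Compound 3 `CCCNC(=O)c1cc(Oc2ccc(NC(=O)c3nn(-c4ccccc4C)c(=O)cc3C)cc2F)ccn1` carries 2-methylphenyl in place of 4-bromo-2-fluorophenyl on an aromatic nitrogen. Within the data shown here, the only measured step bearing on this is a 13-fold higher number from compound 1 to compound 2 (1.12 log units; beyond the scatter), a large one. The change removes the same 4-bromo-2-fluorophenyl, but 2-methylphenyl enters instead of 4-methylphenyl, so that guide is partial. A large step to a lower number in this assay is expected. Compound 3 is estimated at 35000 nM, with an expected range of 9000 nM to 130000 nM. This estimate means an expected 6.7-fold lower number from compound 2 to compound 3 (0.83 log units; beyond the scatter).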

Compound 3, half-maximal inhibitory concentration: 25700 nM
Compound 3: middle estimate off by 1.4-fold (0.13 log units), on the high side; low and high end bracket the measured number.
By their numbers in this assay, from the lowest: compounds 1 and 3 (each within the scatter of the next); then compound 2.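

In this assay, 2-methylphenyl in place of 4-bromo-2-fluorophenyl on the aromatic nitrogen gives a 9.1-fold lower number from compound 2 to compound 3 (0.96 log units; beyond the scatter) and returns the number to the level of compound 1, so this position tolerates a methyl at either of the two ring places shown. Moving that methyl, with 2-methylphenyl in place of 4-methylphenyl, gives a 1.4-fold higher number from compound 1 to compound 3 (0.15 log units; within the scatter) without separating the two isomers. No measured evidence accounts for these differences.

Open, as far as these compounds go, is whether the bromine or the fluorine drives the high number of compound 2, since both leave together in these steps. Also open, from the compounds shown here alone, is how an unsubstituted phenyl or a 4-methoxyphenyl group reads at this position.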